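A few compounds are considered here, and "the series" means these few. Any claim that something is new, unique, unknown or untested is made for them only; others in the source may bear on it.

Measured in a functional assay on HL-60 cells (Homo sapiens) for inhibition, read by MTT assay, with a stated time of 72 h; a higher number here means a weaker inhibitor, a lower number a stronger inhibitor:
- compound 1 `Cc1nc(-c2ccccc2F)c(C(=O)N2CCN(c3cc(Cl)ccc3C)CC2)o1`: 229 nM
- compound 2 `Cc1ccc(C)c(N2CCN(C(=O)c3oc(C)nc3-c3ccccc3F)CC2)c1`: 319 nM
- compound 3 `COc1cc(OC)cc(N2CCN(C(=O)c3oc(C)nc3-c3ccccc3F)CC2)c1`: 10.3 nM

Compound 3 has the lowest number of the three, and both steps leading to it are large: a 22-fold lower number from compound 1 to compound 3 (1.35 log units; beyond the scatter) and a 31-fold lower number from compound 2 to compound 3 (1.49 log units; beyond the scatter). The next compound, compound 4 `Cc1nc(-c2ccccc2F)c(C(=O)N2CCN(c3cccc(Cl)c3)CC2)o1`, has 3-chlorophenyl in place of 3,5-dimethoxyphenyl on an amine nitrogen in a ring. Among the measured compounds shown here, no measured step makes this exact change. The closest evidence is that both compounds without 3,5-dimethoxyphenyl have much higher numbers, and a 1.4-fold higher number from compound 1 to compound 2 (0.14 log units; within the scatter) stays within the scatter. A large rise is therefore expected, with the estimated step being a 15-fold higher number from compound 3 to compound 4 (1.16 log units; beyond the scatter). For compound 4 the estimate is 150 nM, with an expected range of 40 nM to 500 nM.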

Compound 4, half-maximal inhibitory concentration: 39.4 nM
Beside the measured number, compound 4's estimate is 3.8-fold (0.58 log units) above it, outside the stated range (below it).
By their numbers in this assay, from the lowest: compound 3; then compound 4; then compounds 1 and 2 (each within the scatter of the next).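

In this assay, the methoxy groups of compound 3 prove not to be essential for a low number, since the change to 3-chlorophenyl costs only a 3.8-fold higher number from compound 3 to compound 4 (0.58 log units; beyond the scatter). Taking away the methyl on the aromatic carbon of compound 1 gives a 5.8-fold lower number from compound 1 to compound 4 (0.76 log units; beyond the scatter), and 3-chlorophenyl in place of 2,5-dimethylphenyl gives an 8.1-fold lower number from compound 2 to compound 4 (0.91 log units; beyond the scatter), so in both pairs the group without that methyl has the lower number. Nothing measured on these compounds explains these shifts. The compounds shown leave open how a plain phenyl or a 3-methoxyphenyl on the same ring nitrogen would compare, and whether a 3-fluorophenyl would behave like 3-chlorophenyl.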